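The source may report more compounds than this note shows. Statements on the series, on what has been measured and on what is new or still open speak of the compounds shown alone.

The measured compounds in an ADME assay on Vero cells (Chlorocebus sabaeus) for cytotoxicity, read by MTT assay, with a stated time of 72 h; a higher number here means that more compound is tolerated, a lower number that less compound is tolerated:

Compound 1 `CC(C)Cc1ccc(C(=O)/C=C/c2ccc(C(=O)O)cc2)cc1` gives < 10 ug/mL, which is a limit of the assay rather than a number.
Compound 2 `COC(=O)c1cc(-c2cccc(NC(=O)c3ccc(/C=C/C(=O)c4ccc(C)c(F)c4)cc3)c2)on1` gives > 50 ug/mL, again a limit of the assay.
Compound 3 `COC(=O)c1cc(-c2cccc(NC(=O)c3ccc(/C=C/C(=O)c4cccc(OC)c4)cc3)c2)on1` gives > 100 ug/mL, also a limit of the assay.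

Compound 2 therefore stands at a limit in this assay, and none of the three values shown is a number: one sits at the limit of < 10 ug/mL in this assay, at which 1 of the 3 values shown sits, one at the limit of > 50 ug/mL in this assay, at which 1 of the 3 values shown sits, and one at the limit of > 100 ug/mL in this assay, at which 1 of the 3 values shown sits. Compound 4 `COC(=O)c1cc(-c2cccc(NC(=O)c3ccc(/C=C/C(=O)c4ccccc4OC)cc3)c2)on1` differs from compound 2 in a single place: 2-methoxyphenyl in place of 3-fluoro-4-methylphenyl on a carbonyl carbon. Going by the values given here, the only measured step at that carbonyl carbon is a step that the two limits leave unreadable from compound 2 to compound 3, which runs between two limits, so its size cannot be read. Compound 3 carries 3-methoxyphenyl at the same carbonyl carbon and stays at a limit of the assay. Compound 1 differs from compound 2 in more than one place, so its value says nothing about this step. On these numbers no step beyond the usual scatter can be read in either direction, and the step from compound 2 to compound 4 is expected to be a step that the limit leaves unreadable from compound 2 to compound 4. Compound 4 is therefore estimated at 100 ug/mL in this assay, within a range of 40 ug/mL to 250 ug/mL, most likely reported again as a limit.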

Compound 4, half-maximal cytotoxic concentration: > 40 ug/mL
Compound 4: only a limit was reported; the forecaster's own chance of this, stated with the estimate: 80%; the middle value is on the limit's open side.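

Compound 4 gives > 40 ug/mL in this assay, which is a limit of the assay and not a number. The steps linking compound 4 to compound 2 and to compound 3 therefore cannot be read. The compounds shown leave open how compound 2, compound 3 and compound 4 rank in this assay.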